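Aryl Replacements on the Shared Core: Towards Compound 4

This account rests on a few compounds, and the source may have more. Where it says the series, first, only, none or still open, it means among the compounds named here.

Measured so far in a functional assay on Jurkat cells for inhibition of nuclear factor NF-kappa-B complex (Homo sapiens); a higher number here means a weaker inhibitor, a lower number a stronger inhibitor:
compound 1 `CCOC(=O)c1cnc(C)nc1NN1C(=O)C=C(C)C1=O` gives 16000 nM
compound 2 `CCOC(=O)c1cnc(-c2cc(Cl)nc(Cl)c2)nc1NN1C(=O)C=C(C)C1=O` gives 2000 nM
compound 3 `CCOC(=O)c1cnc(-c2ccsc2)nc1NN1C(=O)C=C(C)C1=O` gives 100 nM

Compound 3 holds the lowest number of the three: a 20-fold lower number from compound 2 to compound 3 (1.30 log units; beyond the scatter) and a 160-fold lower number from compound 1 to compound 3 (2.20 log units; beyond the scatter).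

Compound 4 `CCOC(=O)c1cnc(-c2ccc(Cl)s2)nc1NN1C(=O)C=C(C)C1=O` differs from compound 3 in one place: 5-chlorothiophen-2-yl in place of thiophen-3-yl on an aromatic carbon. All measured steps swap the group between two ring nitrogen atoms, para to an ethoxycarbonyl group, so each bears on this one. an 8.0-fold lower number from compound 1 to compound 2 (0.90 log units; beyond the scatter) and a 160-fold lower number from compound 1 to compound 3 (2.20 log units; beyond the scatter) show that an aromatic ring in this place gives a far lower number in this assay than methyl; a 20-fold lower number from compound 2 to compound 3 (1.30 log units; beyond the scatter) shows that which aromatic ring is chosen also matters a great deal. For the measured compounds named here, no measured step adds a chlorine to such a ring or changes the point of attachment of thiophene, so the size of this particular step is not covered by the data. Since compound 4 keeps an aromatic ring here, a number near that of compound 3 is expected, with a modest move in either direction possible; the estimated step is a 2.0-fold higher number from compound 3 to compound 4 (0.30 log units; within the scatter). For compound 4 the estimate in this assay is 200 nM, within 50 nM to 800 nM.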

Compound 4, half-maximal inhibitory concentration: 300 nM
Estimate against measurement, compound 4: 1.5-fold (0.18 log units) below; measured number inside the range.
By their numbers in this assay, from the lowest: compound 3; then compound 4; then compound 2; then compound 1.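

In this assay, 5-chlorothiophen-2-yl keeps most of the gain of an aromatic ring over methyl (a 53-fold lower number from compound 1 to compound 4 (1.73 log units; beyond the scatter)) and also improves on 2,6-dichloropyridin-4-yl (a 6.7-fold lower number from compound 2 to compound 4 (0.82 log units; beyond the scatter)), so both thiophene-bearing compounds, compound 3 and compound 4, have lower numbers than compound 2. Thiophen-3-yl nevertheless remains the better of the two thiophene groups (a 3.0-fold higher number from compound 3 to compound 4 (0.48 log units; beyond the scatter)), which shows that this position still distinguishes between closely related thiophene groups. No evidence is available on the reason for this difference.

From the compounds shown here alone, the step changes the chlorine and the point of attachment together, so their separate contributions remain open, and a plain thiophen-2-yl would help to divide them. Also open, going by these compounds, is how an amine or a carboxylic acid on the thiophene ring, or a phenyl ring in its place, would compare with compound 3.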